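The compounds below may be only part of what the source reports. "The series", "measured", "known", "first", "only" and "open" are said of these compounds alone.

Measured so far in an assay on HEK293 cells for inhibition of neurogenic locus notch homolog protein 1 (Homo sapiens), read by a luciferase reporter and resazurin assay, with a stated time of 16 h; a higher number here means a weaker inhibitor, a lower number a stronger inhibitor:
Compound 1 `CC1=C(C(=O)OC2CCCCC2)C(c2cccc(C(F)(F)F)c2)C2=C(CC(C)(C)CC2=O)N1` gives 14700 nM.
Compound 2 `CC1=C(C(=O)OC2CCN(C(=O)OC(C)(C)C)CC2)C(c2cccc(Br)c2)C2=C(CC(C)(C)CC2=O)N1` gives only a limit, > 10000 nM, which marks the edge of the assay (the limit of > 10000 nM in this assay, at which 1 of the 3 values shown sits).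
Compound 3 `CC1=C(C(=O)OCC2CCN(C(=O)OC(C)(C)C)CC2)C(c2cccc(C#N)c2)C2=C(CC(C)(C)CC2=O)N1` gives 220 nM.

Compound 3 holds the lower of the two real numbers, and its gap to compound 1 lies beyond the usual scatter; compound 2 adds only a limit. Among the measured compounds shown here, no pair of measured compounds differs in a single place, so no measured step is known. Compound 4 `CC1=C(C(=O)OCC2CCN(C(=O)OC(C)(C)C)CC2)C(c2ccc(Br)cc2F)C2=C(CC(C)(C)CC2=O)N1` differs from compound 3 in one place: 4-bromo-2-fluorophenyl in place of 3-cyanophenyl on a saturated ring carbon. Compound 1 and compound 2 carry other groups on that saturated ring carbon together with other esters, so they offer no clean guide. Compound 4 is expected to be a weaker inhibitor, with the step from compound 3 to compound 4 estimated as a 9.1-fold higher number from compound 3 to compound 4 (0.96 log units; beyond the scatter), beyond the scatter. Compound 4 is estimated at 2000 nM, within 400 nM to 10000 nM.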

Compound 4, half-maximal inhibitory concentration: > 10000 nM
Compound 4 gave a limit, no number (the forecaster's own chance of this, stated with the estimate: 25%); middle value at least 5.0-fold (0.69 log units) away from the limit.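

Among the compounds shown here, this is the first measured step at this saturated ring carbon, and it is large: with the rest of the molecule unchanged, 4-bromo-2-fluorophenyl in place of 3-cyanophenyl gives an at least 45-fold higher number from compound 3 to compound 4 (1.65 log units; beyond the scatter). Compound 4 gives a limit and not a number: the limit of > 10000 nM in this assay, at which 2 of the 4 values shown sit. Of the two compounds sharing this ester, only compound 3, with its 3-cyanophenyl, gives a real number.

The compounds shown do not separate the loss of the nitrile from the arrival of the bromine or the fluorine. They also leave open how a ring carrying an amine or a carboxylic acid in place of the nitrile would read in this assay.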